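Swapping the naphthalene amide of compound 3 for a benzothiophene

The compounds below may be only part of what the source reports. "The series", "measured", "known", "first", "only" and "open" are said of these compounds alone.

Three compounds share one core and differ only in the aryl group on the amide carbonyl. Compound 3 `CN1[C@@H]2c3[nH]c4ccccc4c3C[C@H]1[C@H](C#N)N1[C@@H](CNC(=O)c3ccc4ccccc4c3)c3[nH]c4ccccc4c3C[C@@H]21` gives 420 nM in a functional assay on HCT-116 cells (Homo sapiens) for cytotoxicity, read by MTT assay, with a stated time of 72 h (on this read-out higher numbers stand for weaker inhibition and lower numbers for stronger inhibition), the lowest of the three numbers. Compound 1 `CN1[C@@H]2c3[nH]c4ccccc4c3C[C@H]1[C@H](C#N)N1[C@@H](CNC(=O)c3ccc(Cl)cc3)c3[nH]c4ccccc4c3C[C@@H]21` gives 630 nM; the step of a 1.5-fold lower number from compound 1 to compound 3 (0.18 log units; within the scatter) is within the scatter, so the two cannot be ranked. Compound 2 `CN1[C@@H]2c3[nH]c4ccccc4c3C[C@H]1[C@H](C#N)N1[C@@H](CNC(=O)c3cccc4c3CCCC4)c3[nH]c4ccccc4c3C[C@@H]21` gives 4210 nM, and the step of a 10-fold lower number from compound 2 to compound 3 (1.00 log units; beyond the scatter) is beyond the scatter. Compound 4 `CN1[C@@H]2c3[nH]c4ccccc4c3C[C@H]1[C@H](C#N)N1[C@@H](CNC(=O)c3cc4ccccc4s3)c3[nH]c4ccccc4c3C[C@@H]21` carries the change (1-benzothiophen-2-yl in place of naphthalen-2-yl on a carbonyl carbon). Among the compounds with values here, no measured step covers this exact swap; the nearest, a 1.5-fold lower number from compound 1 to compound 3 (0.18 log units; within the scatter), was small. A small step is therefore expected, a 1.2-fold higher number from compound 3 to compound 4 (0.08 log units; within the scatter), with no clear direction. Compound 4 is estimated at 500 nM, in the range 200 nM to 1500 nM.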

Compound 4, half-maximal inhibitory concentration: 500 nM
Compound 4: middle estimate and measured number agree at the digits printed; measured number inside the range.
By their numbers in this assay, from the lowest: compounds 3, 4 and 1 (each within the scatter of the next); then compound 2.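

A five-membered aromatic ring holding a sulfur atom can stand on this carbonyl carbon with no readable shift in this assay: the step of a 1.2-fold higher number from compound 3 to compound 4 (0.08 log units; within the scatter) and the step of a 1.3-fold lower number from compound 1 to compound 4 (0.10 log units; within the scatter) cannot be told from noise. The step of an 8.4-fold lower number from compound 2 to compound 4 (0.93 log units; beyond the scatter) goes beyond the scatter, so the 1,2,3,4-tetrahydronaphthalen-5-yl group alone stands apart among these four amides.

Still open, on these data alone, is how an indol-2-yl or pyridin-3-yl group would read on this carbonyl carbon, or a 1-benzothiophen-2-yl group carrying a carboxylic acid. Nothing given here offers a cause for these numbers.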